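Amide substituent changes on the shared core

The compounds below may be only part of what the source reports. "The series", "measured", "known", "first", "only" and "open" are said of these compounds alone.

Of the compounds shown here, three have been measured in a functional assay on the whole organism for inhibition, with Rattus norvegicus as the target, read by cytopathic effect and paw edema, at a dose of 100 mg/kg by the oral route; on this read-out higher numbers stand for more inhibition at the one dose given (going by the name of the read-out) and lower numbers for less inhibition. Compound 1 `O=C(NCc1ccccc1)c1c(O)c2cccnc2n(-c2ccccc2)c1=O` gives 11.3%. Compound 2 `COc1ccc(NC(=O)c2c(O)c3cccnc3n(-c3ccccc3)c2=O)cc1` gives -1.9%. Compound 3 `Nc1ccc(NC(=O)c2c(O)c3cccnc3n(-c3ccccc3)c2=O)cc1` gives 0%. On these numbers compound 3 stands second highest of the three: its nearest neighbour is compound 2, within the scatter, and the furthest is compound 1, beyond it. The two steps away from compound 1 were a number 13.2 percentage points lower from compound 1 to compound 2 (beyond the scatter) and a number 11.3 percentage points lower from compound 1 to compound 3 (beyond the scatter), while between the two aryl amides the step was a number 1.9 percentage points higher from compound 2 to compound 3 (within the scatter).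

Compound 4 `O=C(Nc1ccncc1)c1c(O)c2cccnc2n(-c2ccccc2)c1=O` carries the change (pyridin-4-yl in place of 4-aminophenyl on an amide-type nitrogen). The step that bears most directly on it is a number 1.9 percentage points higher from compound 2 to compound 3 (within the scatter), where exchanging one group on an aromatic carbon left this assay unchanged within the scatter. Within the data shown here, no measured step replaces the ring itself, so only that close comparison is available. The expectation is therefore a step of a number 2 percentage points higher from compound 3 to compound 4 (within the scatter), no larger than the scatter. Compound 4 is thus expected to give 2%, with a range from -8% to 12%.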

Compound 4, a percentage reported as inhibition, in the whole organism at one dose (the size of the read-out at that dose, not a potency): 24.3%
Estimate against measurement, compound 4: 22.3 percentage points below; measured number above the stated range.
By their numbers in this assay, from the lowest: compounds 2 and 3 (each within the scatter of the next); then compound 1; then compound 4.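

At the amide-type nitrogen, replacing the carbon-only ring itself has a larger outcome in this assay than exchanging a group on that ring did: pyridin-4-yl gives a number 24.3 percentage points higher from compound 3 to compound 4 (beyond the scatter) and a number 26.2 percentage points higher from compound 2 to compound 4 (beyond the scatter), so the ring can move this read-out even though amino and methoxy could not be told apart. Against benzyl the same group gives a number 13 percentage points higher from compound 1 to compound 4 (beyond the scatter), so a ring set directly on the amide-type nitrogen does not by itself bring the lower numbers, with compounds 2 and 3 remaining below compound 1. No measurement offered here accounts for the difference between pyridin-4-yl and 4-aminophenyl.

Still open, going by these compounds, is how unsubstituted phenyl would sit relative to these groups, and whether pyridin-3-yl would match pyridin-4-yl. Pyridin-4-ylmethyl would show whether the gain carries over to the benzyl-type link.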